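The source may hold more compounds than are shown below. What is called first, only, known or untested is meant among the compounds shown, and "the series" means these compounds.

Measured compounds in the series:

Compound 1 `CC1=CC[C@H](C(C)(C)N=C=S)CC1` — in a functional assay on MCF7 cells (Homo sapiens) for inhibition, read by sulforhodamine B assay, with a stated time of 48 h (on this read-out higher numbers stand for weaker inhibition of growth and lower numbers for stronger inhibition of growth), compound 1 gives 57600 nM.
Compound 2 `CC1=CC[C@H](C(C)(C)NC(=S)NN)CC1` — in this assay compound 2 gives 900 nM.
Compound 3 `CC1=CC[C@H](C(C)(C)NC(=S)N/N=C/c2ccc(O)cc2)CC1` — in this assay compound 3 gives > 100000 nM, which is a limit of the assay and not a number.

Where compound 3 stands: it sits at the limit of this assay, the point described by the limit of > 100000 nM in this assay, at which 1 of the 3 values shown sits. Among the compounds with a number, compound 2 is the lower one, and the step of a 64-fold lower number from compound 1 to compound 2 (1.81 log units; beyond the scatter) is the only measured step in the series. Compound 3 carries the 4-hydroxyphenyl extension on the same thiosemicarbazide core and is at the limit, so no number places it relative to compound 2.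

Compound 4 `CC1=CC[C@H](C(C)(C)NC(=S)N/N=C/c2ccc(Cl)cc2)CC1` differs from compound 3 only by chloro in place of hydroxy on an aromatic carbon. Among the compounds with values here, the measured step of a 64-fold lower number from compound 1 to compound 2 (1.81 log units; beyond the scatter) concerns the saturated chain carbon and not the aromatic ring; no measured pair separates hydroxy from chloro on that ring. The starting point for the change is a limit, so any expectation for compound 4 is weakly anchored. On the data shown, compound 4 is expected to remain in the weak range of this assay, with an estimated value of 90000 nM, between 20000 nM and 300000 nM, and a substantial chance that only a limit is again reported. The step of an at least 1.1-fold lower number from compound 3 to compound 4 (0.04 log units; that floor lies within the scatter) that this estimate implies is expected to be none beyond the scatter.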

Compound 4, concentration for 50% growth inhibition: 18300 nM
Estimate against measurement, compound 4: 4.9-fold (0.69 log units) above; the measured number lies below the stated range.
By their numbers in this assay, from the lowest: compound 2; then compound 4; then compound 1. At a limit, above all of these: compound 3.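

In this assay, the change from 4-hydroxyphenyl to 4-chlorophenyl gives an at least 5.4-fold lower number from compound 3 to compound 4 (0.73 log units; beyond the scatter), which shows that the group on this aromatic carbon, para to a large group, bears on the read-out, something the earlier step on the saturated chain carbon could not show. Compound 3 gives > 100000 nM, which is a limit of the assay and not a number. The size of the step is therefore only a floor, since one end of it rests on that limit: the limit of > 100000 nM in this assay, at which 1 of the 4 values shown sits.

The compounds shown hold only hydroxy and chloro at this place, so the true size of the step stays open, as does how a fluoro, a methoxy or an amine would read there. Within the data shown here, no pair differing in one place joins compound 4 to compound 2, so what the 4-chlorophenyl group adds to the shared core cannot be read from these data.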